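Working notes: from compound 2 to compound 3

This account rests on a few compounds, and the source may have more. Where it says the series, first, only, none or still open, it means among the compounds named here.

Values in a functional assay on KB cells (Homo sapiens) for antiproliferative activity, read by sulforhodamine B assay, with a stated time of 48 h; a higher number here means a weaker inhibitor of growth, a lower number a stronger inhibitor of growth:
- compound 1 `COc1ccc(S(=O)(=O)Nc2ccccc2CCc2ccc(C(=O)Nc3ccccc3N)cc2)cc1` gives 23 nM
- compound 2 `COc1cccc(S(=O)(=O)Nc2ccccc2CCc2ccc(C(=O)Nc3ccccc3N)cc2)c1` gives 462 nM

Of these two numbers, the higher belongs to compound 2, at 462 nM. Among the compounds with values here, the only measured step is a 20-fold higher number from compound 1 to compound 2 (1.30 log units; beyond the scatter), with 3-methoxyphenyl in place of 4-methoxyphenyl on a sulfonyl sulfur.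

Compound 3 `Nc1ccccc1NC(=O)c1ccc(CCc2ccccc2NS(=O)(=O)c2ccc(F)cc2)cc1` is still unmeasured. It keeps the shared core and carries 4-fluorophenyl in place of 3-methoxyphenyl on a sulfonyl sulfur.

Within the data shown here, the same 3-methoxyphenyl group leaves here, so the single large step above is the only guide. Among the measured compounds shown here, no measured compound carries 4-fluorophenyl, and two compounds cannot show how closely it will follow 4-methoxyphenyl. A sizeable move to a lower number in this assay is therefore expected, though probably not one that recovers the whole of the measured step. The estimate means a 6.6-fold lower number from compound 2 to compound 3 (0.82 log units; beyond the scatter), an expected change well beyond the scatter. For compound 3 the estimated value is 70 nM, with an expected range from 20 nM to 300 nM.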

Compound 3, concentration for 50% growth inhibition: 884 nM
Compound 3: middle estimate off by 13-fold (1.10 log units), on the low side; the measured number lies above the stated range.
By their numbers in this assay, from the lowest: compound 1; then compounds 2 and 3 (each within the scatter of the next).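

In this assay, exchanging methoxy for fluoro on the aromatic carbon gives a 38-fold higher number from compound 1 to compound 3 (1.58 log units; beyond the scatter), so among these compounds the low number of compound 1 belongs to 4-methoxyphenyl specifically and does not extend to 4-fluorophenyl, even though both names carry their substituent at the 4 position. The exchange of groups on the sulfonyl sulfur gives a 1.9-fold higher number from compound 2 to compound 3 (0.28 log units; within the scatter), which leaves 3-methoxyphenyl and 4-fluorophenyl indistinguishable here; compound 1 thus stands alone, with compounds 2 and 3 together on the other side of a large gap, rather than the first step being one end of a graded change. No measurement on hand bears on the reason for this result.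

The compounds shown leave open whether other groups on the sulfonyl sulfur, such as 4-ethoxyphenyl, 4-hydroxyphenyl or 4-chlorophenyl, would stay close to compound 1 or fall with compounds 2 and 3. They also leave open where unsubstituted phenyl or 3-fluorophenyl would stand, and so whether the methoxy group lowers the number from a plain phenyl baseline or the other groups raise it.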